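The source may hold more compounds than are shown below. What is called first, only, known or untested is meant among the compounds shown, and "the series" means these compounds.

Three compounds carry the same core and differ only in the group attached to the amide-type nitrogen. Compound 1 `Cc1ccc(NC(=O)COc2ccc3cc(/C=C4/SC(=O)NC4=O)ccc3c2)cc1` bears a 4-methylphenyl there, and in an assay on isolated protein for inhibition of histone deacetylase 8 (Homo sapiens), with a stated time of 1 h (on this read-out lower numbers stand for stronger inhibition and higher numbers for weaker inhibition), compound 1 gives 9000 nM. Compound 2 `O=C(COc1ccc2cc(/C=C3/SC(=O)NC3=O)ccc2c1)Nc1cccc(C(F)(F)F)c1` carries a 3-(trifluoromethyl)phenyl instead; in this assay compound 2 returns only a limit, > 50000 nM, as noted in the limit of > 50000 nM in this assay, at which 1 of the 3 values shown sits. Compound 3 `Cc1cccc2sc(NC(=O)COc3ccc4cc(/C=C5/SC(=O)NC5=O)ccc4c3)nc12` carries a 4-methyl-1,3-benzothiazol-2-yl, and in this assay compound 3 gives 5800 nM. Compound 3 thus holds the lowest number of the two numbers shown, but the step of a 1.6-fold lower number from compound 1 to compound 3 (0.19 log units; within the scatter) lies within the scatter, so compound 1 and compound 3 cannot be ranked against each other. The group on the nitrogen can nevertheless matter a great deal: an at least 5.5-fold higher number from compound 1 to compound 2 (0.74 log units; beyond the scatter) and an at least 8.6-fold lower number from compound 2 to compound 3 (0.93 log units; beyond the scatter).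

Compound 4 `Cc1cc(NC(=O)COc2ccc3cc(/C=C4/SC(=O)NC4=O)ccc3c2)no1` is not yet measured. Relative to compound 3 the change is 5-methyl-1,2-oxazol-3-yl in place of 4-methyl-1,3-benzothiazol-2-yl on an amide-type nitrogen. Among the measured compounds shown here, no measured step covers this exact swap; the two steps beyond the scatter both involve compound 2, whose value is a limit. Given that the smaller aromatic groups on this nitrogen have so far given numbers no lower than that of compound 3, compound 4 is expected to give 15000 nM, between 4000 nM and 50000 nM, a step of a 2.6-fold higher number from compound 3 to compound 4 (0.41 log units; beyond the scatter).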

Compound 4, half-maximal inhibitory concentration: > 50000 nM
Compound 4: a limit, no number (the forecaster's own chance of this, stated with the estimate: 25%); middle value at least 3.3-fold (0.52 log units) away from the limit.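

The swap in an at least 8.6-fold higher number from compound 3 to compound 4 (0.93 log units; beyond the scatter) removes the six-membered aromatic ring of carbon only, leaving a group with fewer heavy atoms, while the five-membered aromatic ring with 2 hetero atoms and the counts of hydrogen-bond donors and acceptors stay the same. Those shared features are therefore not enough on their own to keep the number seen for compound 3, and the new group also compares poorly with the 4-methylphenyl, as an at least 5.5-fold higher number from compound 1 to compound 4 (0.74 log units; beyond the scatter) shows. Compound 4 returns only a limit, so its true value stays unknown, the step from compound 2 to compound 4 cannot be read, and two compounds now rest at the top of the measurable range: the limit of > 50000 nM in this assay, at which 2 of the 4 values shown sit.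

The compounds shown do not separate the loss of the six-membered ring from the change of sulfur to oxygen, which a 5-methyl-1,3-thiazol-2-yl group on this nitrogen could help to tease apart. Every group shown on this nitrogen is aromatic, so the effect of a cyclohexyl group or of a chain ending in an amine or a carboxylic acid remains open.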